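Dropping one chloro from a dichloro benzyl-linked core

The source may report more compounds than this note shows. Statements on the series, on what has been measured and on what is new or still open speak of the compounds shown alone.

Compound 1 `ClCc1ccc(Cn2cnc3c(Cl)ncnc32)cc1` — 3540 nM
Compound 2 `ClCc1ccc(Cn2cnc3nc(Cl)nc(Cl)c32)cc1` — 1770 nM
Compound 3 `ClCc1cccc(Cn2cnc3nc(Cl)nc(Cl)c32)c1` — 1810 nM

In a functional assay on NCI-H522 cells (Homo sapiens) for cytotoxicity, read by sulforhodamine B assay, with a stated time of 48 h (a lower number here means a stronger inhibitor of growth, a higher number a weaker inhibitor of growth), compound 2 gives the lowest of the three numbers, but its neighbours sit within the scatter: compound 3 gives 1810 nM and compound 1 gives 3540 nM, so no order among them can be read. Compound 4 `ClCc1ccc(Cn2cnc3ncnc(Cl)c32)cc1` has not been measured; it differs from compound 2 by hydrogen in place of chloro on an aromatic carbon. Going by the values given here, no measured pair shows this change on its own, so the size of the step is uncertain. Compound 1, which carries a single chloro on a differently attached core, sits within the scatter of compound 2, and on that basis the loss of a chloro is expected to cost little. Compound 4 is therefore estimated at 3000 nM (range 1200 nM to 8000 nM), an expected step of a 1.7-fold higher number from compound 2 to compound 4 (0.23 log units; within the scatter).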

Compound 4, concentration for 50% growth inhibition: 4260 nM
Compound 4: the middle estimate sits 1.4-fold (0.15 log units) below what was measured, and the stated range covers the measured number.
By their numbers in this assay, from the lowest: compounds 2, 3, 1 and 4 (each within the scatter of the next, the first and the last beyond it).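

In this assay, going by these compounds alone, hydrogen in place of chloro on the aromatic carbon between two ring nitrogen atoms gives a 2.4-fold higher number from compound 2 to compound 4 (0.38 log units; beyond the scatter) and is the only single change measured on its own in this set. Within the data shown here, this chloro therefore makes a modest but readable difference to growth inhibition, which comparisons among the earlier compounds could not show. Nothing measured here bears on the reason for this step. Still open, going by these compounds, is how an amine or a methoxy group at this position would compare with chloro and hydrogen, and whether the same step holds on the core of compound 3.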